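A few compounds are considered here, and "the series" means these few. Any claim that something is new, unique, unknown or untested is made for them only; others in the source may bear on it.

Within the data shown here, in an ADME assay on MDCK cells (Canis lupus familiaris) for cytotoxicity, read by MTT assay, with a stated time of 24 h (a lower number here means that less compound is tolerated, a higher number that more compound is tolerated), compound 2 `O=S(=O)(NCc1csc2ccccc12)c1ccc(C(F)(F)F)cc1` gives 94800 nM, the only actual number available so far. Compound 1 `O=[N+]([O-])c1ccc(S(=O)(=O)NCc2csc3ccccc23)cc1` is reported only as a limit of the assay, > 191000 nM. Compound 3 `CC(=O)c1ccc(S(=O)(=O)NCc2csc3ccccc23)cc1` shares the core of compound 2 and differs from it at one place, on an aromatic carbon of a six-membered aromatic ring of carbon only, para to a large group: acetyl in place of trifluoromethyl on an aromatic carbon. Among the measured compounds shown here, one measured step bears on this change, trifluoromethyl in place of nitro on an aromatic carbon, and it is an at least 2.0-fold lower number from compound 1 to compound 2 (0.30 log units; that floor lies within the scatter). For the measured compounds named here, with only that step as a guide, no step beyond the usual scatter is expected in this assay. The estimated step is a 1.3-fold higher number from compound 2 to compound 3 (0.10 log units; within the scatter). For compound 3 the estimated value is 120000 nM, with an expected range from 55000 nM to 230000 nM.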

Compound 3, half-maximal cytotoxic concentration: > 193000 nM
Compound 3 ended at the assay's limit; the forecaster's own chance of this, stated with the estimate: 30%; middle value at least 1.6-fold (0.20 log units) away from the limit.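

In this assay compound 3 is reported only as a limit of the assay, > 193000 nM. Replacing trifluoromethyl with acetyl on this aromatic carbon gives an at least 2.0-fold higher number from compound 2 to compound 3 (0.30 log units; that floor lies within the scatter), so the smallest step the data allow does not by itself separate the two compounds. Compound 2 remains the only one of the three with an actual number, and acetyl is now the second group at this position, after nitro, to end at a limit instead.

On these data alone, the step from compound 1 to compound 3 cannot be read, and how far either compound lies beyond its limit stays unknown. Among these compounds, it also remains open whether an amine or a carboxylic acid at this position would give an actual number in this assay, and how that number would compare with the one for compound 2.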